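Adding a Trifluoromethyl Group to the Benzyl Ester of Compound 1

The source may hold more compounds than are shown below. What is called first, only, known or untested is meant among the compounds shown, and "the series" means these compounds.

Compound 1 `O=C(OCc1ccccc1)c1cccc(=O)[nH]1` is a small ester on a shared core. In an assay on isolated protein for inhibition of matrix metalloproteinase-9 (Homo sapiens) (on this read-out lower numbers stand for stronger inhibition and higher numbers for weaker inhibition), compound 1 gives 69000 nM. Two close relatives have been measured beside it. Compound 2 `O=C(OCc1cccc(F)c1)c1cccc(=O)[nH]1` carries a fluoro in place of hydrogen on an aromatic carbon, and in this assay compound 2 gives 50000 nM. Compound 3 `O=C(OCc1ccccc1Cl)c1cccc(=O)[nH]1` carries a chloro in place of hydrogen on an aromatic carbon, and compound 3 gives 81000 nM. Among these three numbers compound 1 stands second highest; the step of a 1.2-fold higher number from compound 1 to compound 3 (0.07 log units; within the scatter) and the step of a 1.4-fold lower number from compound 1 to compound 2 (0.14 log units; within the scatter) both stay inside the usual scatter, so none of the three can be ranked above the others.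

Compound 4 `O=C(OCc1ccc(C(F)(F)F)cc1)c1cccc(=O)[nH]1` has not yet been measured. It differs from compound 1 in one place: trifluoromethyl in place of hydrogen on an aromatic carbon, the new group sitting para to a large group. The measured steps that bear on this change are the two small substitutions on the same ring, from compound 1 to compound 2 and from compound 1 to compound 3, and neither moved the number beyond the scatter. A step no larger than the scatter is therefore expected in this assay, in either direction. The estimate for compound 4 is 60000 nM, with a range from 30000 nM to 120000 nM. This estimate means an expected step of a 1.2-fold lower number from compound 1 to compound 4 (0.06 log units; within the scatter).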

Compound 4, half-maximal inhibitory concentration: 101000 nM
Compound 4: middle estimate off by 1.7-fold (0.23 log units), on the low side; the range from low to high includes it.
By their numbers in this assay, from the lowest: compounds 2, 1, 3 and 4 (each within the scatter of the next, the first and the last beyond it).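

In this assay, trifluoromethyl on an aromatic carbon, para to a large group, gives a 1.5-fold higher number from compound 1 to compound 4 (0.17 log units; within the scatter), so even this substituent of 4 heavy atoms leaves the number inside the scatter. The earlier steps shown here on this ring replaced a hydrogen with only a fluoro or a chloro, so they could not show whether a group with more heavy atoms would be accommodated without a clear change; for this one place and this one group, the answer is that no change can be read. No accompanying measurement bears on why the step stays this small.

The compounds shown leave open whether a group of a different kind at this same place, such as an amine, a carboxylic acid or a longer chain, would move the number beyond the scatter in either direction. They also leave open whether trifluoromethyl would behave the same way on other carbons of this ring, since a single substituted position cannot stand for the whole ring.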